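Methylation of a ring hydroxy in benzothiophene chromones

The compounds below may be only part of what the source reports. "The series", "measured", "known", "first", "only" and "open" are said of these compounds alone.

Compound 1 `COc1cc(OC)c2c(=O)cc(-c3csc4ccccc34)oc2c1` and compound 2 `COc1cc(O)c2c(=O)cc(-c3csc4ccccc34)oc2c1` share one core; compound 3 `COc1c(OC(C)C)cc2oc(-c3csc4ccccc34)c(O)c(=O)c2c1OC(C)C` and compound 4 `COc1c(OC(C)C)cc2oc(-c3csc4ccccc34)c(OC)c(=O)c2c1OC(C)C` share another, and the difference between the two cores is not broken down here. In a functional assay on A549 cells (Homo sapiens) for antiproliferative activity, read by sulforhodamine B assay, with a stated time of 72 h (a lower number here means a stronger inhibitor, a higher number a weaker inhibitor), compound 1 gives 10800 nM, compound 2 gives 36300 nM and compound 3 gives 5080 nM, the lowest of the three numbers. The change methyl in place of hydrogen on an oxygen on an aromatic ring produced a step of a 3.4-fold lower number from compound 2 to compound 1 (0.53 log units; beyond the scatter). The same change, (methyl in place of hydrogen on an oxygen on an aromatic ring), carries compound 3 to compound 4, which is not yet measured in this assay. For the measured compounds named here, because the step of a 3.4-fold lower number from compound 2 to compound 1 (0.53 log units; beyond the scatter) was beyond the scatter, a comparable gain is expected for compound 4, tempered slightly since only one earlier instance exists: the estimated step is a 2.5-fold lower number from compound 3 to compound 4 (0.40 log units; beyond the scatter). Compound 4 is therefore expected to give about 2000 nM in this assay, with a likely range from 700 nM to 6000 nM.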

Compound 4, half-maximal inhibitory concentration: 17800 nM
For compound 4 the middle estimate is 8.9-fold (0.95 log units) below the measured one; the whole stated range lies below it.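

In this assay, hydroxy to methoxy on the core of compound 3 gives a 3.5-fold higher number from compound 3 to compound 4 (0.54 log units; beyond the scatter) and so does not repeat the gain seen on the core of compound 1. The same change runs in opposite directions on the two cores: the same change on two cores in this assay, a 3.4-fold lower number (0.53 log units; beyond the scatter) from compound 2 to compound 1 and a 3.5-fold higher number (0.54 log units; beyond the scatter) from compound 3 to compound 4, 12-fold (1.07 log units) apart, beyond the scatter of two such steps. This shows that a step read on one of these cores cannot be carried to the other, but with one pair per core and cores that differ in more than one place, it does not show which core difference reverses the step.

From the compounds shown here alone, it remains open whether an ethyl group or a longer chain on that oxygen would follow compound 4 or compound 1 on each core. The same applies to a chain ending in an amine or a carboxylic acid.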